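Swapping a difluorophenyl ring for a dihydropyran: solubility outlook

A few compounds are considered here, and "the series" means these few. Any claim that something is new, unique, unknown or untested is made for them only; others in the source may bear on it.

Three measured compounds share one core and differ only in the group carried on an aromatic carbon of it. Compound 1 is `Cc1cc(NCc2ccccn2)n2ncc(-c3ccc(C#N)cc3)c2n1`, compound 2 is `Cc1cc(NCc2ccccn2)n2ncc(-c3c(C)cccc3C)c2n1` and compound 3 is `Cc1cc(NCc2ccccn2)n2ncc(-c3ccc(F)cc3F)c2n1`. In a physicochemical assay for solubility, read by HPLC, using the shake flask method, measured as kinetic solubility, with a stated time of 2 h, at pH 7.4 (on this read-out lower numbers stand for lower solubility and higher numbers for higher solubility), compound 1 gives < 5000 nM, which is a limit of the assay rather than a number. Compound 2 in this assay likewise gives only a limit, < 5000 nM. Compound 3, the starting point followed here, gives in this assay the limit < 5000 nM. Because (the limit of < 5000 nM in this assay, at which 3 of the 3 values shown sit), no step among these three can be read: a step that the two limits leave unreadable from compound 1 to compound 2, a step that the two limits leave unreadable from compound 1 to compound 3 and a step that the two limits leave unreadable from compound 2 to compound 3.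

Compound 4 is `Cc1cc(NCc2ccccn2)n2ncc(C3=CCOCC3)c2n1`. Its change from compound 3 is a group of 6 heavy atoms (5 carbon, 1 oxygen; one six-membered non-aromatic ring with 1 hetero atom) in place of a group of 8 heavy atoms (6 carbon, 2 fluorine; one six-membered aromatic ring of carbon only), on an aromatic carbon, the entering ring being a six-membered non-aromatic ring with one hetero atom and one double bond outside aromatic rings, and the departing ring an aromatic ring of carbon only.

Going by the values given here, none of the measured steps gives a size to work from, so nothing here tells whether this change moves solubility at all. The expected step is an at least 1.4-fold higher number from compound 3 to compound 4 (0.14 log units; that floor lies within the scatter), counted from the limit at which compound 3 sits. For compound 4 the estimate in this assay is 7000 nM, with a range from 1500 nM to 30000 nM.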

Compound 4, solubility: 171000 nM
Compound 4: middle estimate off by 24-fold (1.39 log units), on the low side; measured number outside the range, above it.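

This position, on an aromatic carbon of the shared core, turns out to be one where the read-out can move well clear of the assay limit, which the earlier compounds could not show: the limit of < 5000 nM in this assay, at which 3 of the 4 values shown sit.

In this assay, replacing the 2,4-difluorophenyl group with the six-membered non-aromatic ring with 1 hetero atom gives an at least 34-fold higher number from compound 3 to compound 4 (1.53 log units; beyond the scatter), and the two other aromatic groups give the same reading, with an at least 34-fold higher number from compound 2 to compound 4 (1.53 log units; beyond the scatter) and an at least 34-fold higher number from compound 1 to compound 4 (1.53 log units; beyond the scatter). All three steps are counted from limits, so each gives only a floor for the size of the change, while the steps among compound 1, compound 2 and compound 3 still cannot be read.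

The compounds shown do not separate what losing the aromatic ring contributes from what the ring oxygen contributes, and a cyclohexenyl ring of carbon only, placed on the same carbon, would speak to that. On these data alone, whether the same kind of step holds for the fully saturated tetrahydropyran ring, or for a ring carrying an amine such as piperidine, also remains open.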